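From Furan to Pyridine on the Shared Core

A few compounds are considered here, and "the series" means these few. Any claim that something is new, unique, unknown or untested is made for them only; others in the source may bear on it.

Among the measured compounds shown here, compound 2 `Oc1ccc(-c2cc(-c3ccoc3)cc(-c3ccc(O)cc3)n2)cc1` is the only compound here with a number in a functional assay on HCT-15 cells (Homo sapiens) for cytotoxicity, read by CCK-8 assay (on this read-out lower numbers stand for stronger inhibition and higher numbers for weaker inhibition), where compound 2 gives 1530 nM. Compound 1 `Oc1ccc(-c2cc(-c3ccoc3)cc(-c3ccccc3O)n2)cc1` reaches only a limit of the assay, > 50000 nM. For the measured compounds named here, the one measured step, an at least 32-fold lower number from compound 1 to compound 2 (1.51 log units; beyond the scatter), rests on that limit of > 50000 nM in this assay, at which 1 of the 2 values shown sits, and concerns the hydroxyphenyl group, not the ring that changes next. Compound 3 `Oc1ccc(-c2cc(-c3cccnc3)cc(-c3ccc(O)cc3)n2)cc1` differs from compound 2 by pyridin-3-yl in place of furan-3-yl on an aromatic carbon. Going by the values given here, no measured step covers this exchange of one five-membered aromatic ring with 1 hetero atom for one six-membered aromatic ring with 1 hetero atom, and the hydrogen-bond donor and acceptor counts are unchanged. In this assay the step of a 1.4-fold higher number from compound 2 to compound 3 (0.16 log units; within the scatter) is therefore expected to stay within the scatter, with some room for a weaker number. Compound 3 is estimated at 2200 nM, with a range from 600 nM to 8000 nM.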

Compound 3, half-maximal inhibitory concentration: 840 nM
Beside the measured number, compound 3's estimate is 2.6-fold (0.42 log units) above it, and the stated range covers the measured number.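

In this assay the exchange of furan-3-yl for pyridin-3-yl, on the aromatic carbon opposite the ring nitrogen, gives a 1.8-fold lower number from compound 2 to compound 3 (0.26 log units; within the scatter) and so leaves the two rings indistinguishable on this read-out. Among the compounds shown here, the earlier compounds offered only a step in the hydroxyphenyl group that rested on a limit, whereas this is the first step read between two actual numbers and the first at this position. With both 4-hydroxyphenyl groups kept, this position accepts a six-membered aromatic ring with 1 hetero atom in place of a five-membered one, with no difference beyond the scatter.

Still open, as far as these compounds go, is whether the number would hold with an amine, a carboxylic acid or a longer alkyl chain at this position instead of an aromatic ring. Nothing given here bears on why the two rings read alike.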